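Chloro for hydrogen on the aromatic ring of compound 2

The compounds below may be only part of what the source reports. "The series", "measured", "known", "first", "only" and "open" are said of these compounds alone.

Of the compounds shown here, two have been measured. Compound 1 `COC(=O)[C@@]1(C)CCC=C2[C@@H]1CC[C@@H](C)[C@]2(C)Cc1c(C)[nH]c2c(Br)cccc12` and compound 2 `COC(=O)[C@@]1(C)CC[C@@H]2C3=C1CC[C@@H](C)[C@]3(C)C[C@@H]1c3ccccc3N[C@H]21` were both run in a functional assay on T47D cells (Homo sapiens) for inhibition, read by sulforhodamine B assay, with a stated time of 48 h; a lower number here means a stronger inhibitor of growth, a higher number a weaker inhibitor of growth. Compound 1 gives 31000 nM. Compound 2 gives 35000 nM, the higher of the two numbers, but the two values lie within the scatter of each other, so nothing separates compound 1 from compound 2 on these data. Going by the values given here, no pair of measured compounds differing in a single place exists, so no measured step is available to guide the next change.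

Compound 3 `COC(=O)[C@@]1(C)CC[C@@H]2C3=C1CC[C@@H](C)[C@]3(C)C[C@@H]1c3cc(Cl)ccc3N[C@H]21` has not yet been measured in this assay. Relative to compound 2 it carries chloro in place of hydrogen on an aromatic carbon, that is, chloro in place of hydrogen on an aromatic carbon. Among the compounds with values here, with no measured step to draw on and both known values close together, the step of a 1.2-fold lower number from compound 2 to compound 3 (0.07 log units; within the scatter) is expected to be no larger than the scatter, in no particular direction. Compound 3 is therefore estimated at 30000 nM, with a range from 10000 nM to 90000 nM.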

Compound 3, concentration for 50% growth inhibition: 28000 nM
Beside the measured number, compound 3's estimate is 1.1-fold (0.03 log units) above it; low and high end bracket the measured number.
By their numbers in this assay, from the lowest: compounds 3, 1 and 2 (each within the scatter of the next).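

In this assay, going by these compounds alone, chloro in place of hydrogen on an aromatic carbon gives a 1.3-fold lower number from compound 2 to compound 3 (0.10 log units; within the scatter) and this is the first single-place step, since no pair among the earlier compounds differed in one place only. At this position, para to a fused ring and meta to a fused ring, the chlorine atom therefore leaves compound 3 not separated from compound 2 by this read-out, so a single heavy atom here shows no measurable consequence for growth inhibition in these cells. No measurement at hand accounts for the size of this step, and no cause is assigned to it.

On these data alone, it remains open whether a methoxy group, an amine or a carboxylic acid on this same aromatic carbon would give a step beyond the scatter, and whether chloro on the other carbons of this six-membered aromatic ring would read as it does here. Also open, as far as these compounds go, is whether any change away from this ring, such as a carboxylic acid in place of the methyl ester shared by compounds 1, 2 and 3, would separate a compound from the others.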